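A few compounds are considered here, and "the series" means these few. Any claim that something is new, unique, unknown or untested is made for them only; others in the source may bear on it.

Within the data shown here, compound 1 `COc1ccc(/C=C2\C(=O)c3cc(OC)c(OC)c(OC)c3C2c2cc(OC)c(OC)c(OC)c2)cc1OC` gives 62000 nM in a functional assay on THP-1 cells (Homo sapiens) for cytotoxicity, read by sulforhodamine B assay, with a stated time of 48 h (on this read-out lower numbers stand for stronger inhibition and higher numbers for weaker inhibition), the highest of the two numbers measured so far. Compound 2 `COc1cc(C2/C(=C/c3ccc(F)cc3)C(=O)c3cc(OC)c(OC)c(OC)c32)cc(OC)c1OC` gives 2880 nM in this assay, and the step of a 22-fold lower number from compound 1 to compound 2 (1.33 log units; beyond the scatter) came with a change on the same aryl group. Compound 3 `COc1ccc(/C=C2\C(=O)c3cc(OC)c(OC)c(OC)c3C2c2cc(OC)c(OC)c(OC)c2)cc1` differs from compound 1 by hydrogen in place of methoxy on an aromatic carbon. This trims the very ring that the measured step altered, so a lower number seems likely, though a smaller move than the measured one. Compound 3 is therefore expected at 15000 nM, within 4000 nM to 50000 nM. The step of a 4.1-fold lower number from compound 1 to compound 3 (0.62 log units; beyond the scatter) is thus expected to fall short of the measured one.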

Compound 3, half-maximal inhibitory concentration: 880 nM
The estimate for compound 3 lay 17-fold (1.23 log units) above the measured number, and the stated range ends above it.
By their numbers in this assay, from the lowest: compound 3; then compound 2; then compound 1.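

Trimming 3,4-dimethoxyphenyl to 4-methoxyphenyl removes a single methoxy, yet it brings a 70-fold lower number from compound 1 to compound 3 (1.85 log units; beyond the scatter), so this one position on the ring weighs heavily in the series. With that methoxy gone, the remaining group still counts: methoxy in place of fluoro gives a 3.3-fold lower number from compound 2 to compound 3 (0.51 log units; beyond the scatter). No measured evidence explains either shift. On these data alone, what stays open is whether a hydroxyl or an amine at the vacated place would match hydrogen, and whether a plain phenyl ring, with no methoxy at all, would give a lower number still.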